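Removing the Methoxy from the Outer Ring of Compound 2

A few compounds are considered here, and "the series" means these few. Any claim that something is new, unique, unknown or untested is made for them only; others in the source may bear on it.

Compound 1 `COc1ccccc1/C=C/C(=O)/C=C/c1ccc(OCc2cn(CCOc3cc(=O)oc4ccccc34)nn2)c(OC)c1`, compound 2 `COc1ccccc1/C=C/C(=O)/C=C/c1ccc(OCc2cn(CCCCOc3cc(=O)oc4ccccc34)nn2)c(OC)c1` and compound 3 `COc1cccc(/C=C/C(=O)/C=C/c2ccc(OCc3cn(CCOc4cc(=O)oc5ccccc45)nn3)c(OC)c2)c1` share one core. In a functional assay on COLO 205 cells (Homo sapiens) for inhibition, read by sulforhodamine B assay, with a stated time of 48 h, tested at 50 uM (on this read-out higher numbers stand for more inhibition of growth at the one concentration tested and lower numbers for less inhibition of growth), compound 1 gives 67%, compound 2 gives 47% and compound 3 gives 69%, so compound 2 stands lowest of the three. For the measured compounds named here, the one measured step, a number 2 percentage points higher from compound 1 to compound 3 (within the scatter), replaced a 2-methoxyphenyl by a 3-methoxyphenyl. Compound 4 `COc1cc(/C=C/C(=O)/C=C/c2ccccc2)ccc1OCc1cn(CCCCOc2cc(=O)oc3ccccc23)nn1` differs from compound 2 by hydrogen in place of methoxy on an aromatic carbon. Going by the values given here, no measured pair removes that methoxy entirely; the nearest guide is the change from 2-methoxyphenyl to 3-methoxyphenyl, which stayed within the scatter. A step of about a number 2 percentage points lower from compound 2 to compound 4 (within the scatter) is therefore expected. Compound 4 is estimated at 45%, within 25% to 65%.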

Compound 4, percent growth inhibition at one concentration: 31%
Estimate against measurement, compound 4: 14 percentage points above; the range from low to high includes it.
By their numbers in this assay, from the lowest: compound 4; then compound 2; then compounds 1 and 3 (each within the scatter of the next).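

In this assay the change from 2-methoxyphenyl to phenyl gives a number 16 percentage points lower from compound 2 to compound 4 (beyond the scatter) and so goes beyond the scatter, whereas moving the methoxy to give 3-methoxyphenyl, in the pair with the chain of compound 1, stayed within it. On the compounds shown, removing this methoxy therefore matters where moving it did not. Nothing measured here explains the drop.

From the compounds shown here alone, it remains open whether an amine or a hydroxyl on this ring would give a higher number. Going by these compounds, it is also open whether the same removal would give a similar step with the chain of compound 1.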